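Moving the Fluorine on the Oxadiazole Aryl Ring

This account rests on a few compounds, and the source may have more. Where it says the series, first, only, none or still open, it means among the compounds named here.

Compound 1 `Cc1cc(Cl)ccc1OCc1nnc(-c2ccccc2F)o1`: a limit in an ADME assay on cells for inhibition of anoctamin-2 (Homo sapiens), read by fluorescence, with a stated time of 20 min (a higher number here means a weaker inhibitor, a lower number a stronger inhibitor), > 100000 nM
Compound 2 `Cc1cc(Cl)ccc1OC(C)(C)C(=O)N/N=C/c1ccccc1OC(F)(F)F`: a limit, > 100000 nM
Compound 3 `Cc1cc(Cl)ccc1OCc1nnc(-c2ccccc2C(F)(F)F)o1`: a limit, > 100000 nM

Compound 1 stands where every measured compound here stands, at the limit of > 100000 nM in this assay, at which 3 of the 3 values shown sit; it has no number of its own. Among the compounds with values here, the only single-point step that touches it, a step that the two limits leave unreadable from compound 1 to compound 3, cannot be read for size because of the limit of > 100000 nM in this assay, at which 3 of the 3 values shown sit. Compound 4 `Cc1cc(Cl)ccc1OCc1nnc(-c2cccc(F)c2)o1` differs from compound 1 by 3-fluorophenyl in place of 2-fluorophenyl on an aromatic carbon. Within the data shown here, no measured step bears readably on this change, so nothing points to a shift beyond the scatter in this assay, and compound 4 is expected to sit at the limit as well. The estimate for compound 4 is 150000 nM, with a range from 40000 nM to 600000 nM. That estimate means an expected step that the limit leaves unreadable from compound 1 to compound 4.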

Compound 4, half-maximal inhibitory concentration: > 100000 nM
Compound 4 ended at the assay's limit (the forecaster's own chance of this, stated with the estimate: 75%); the middle value does not contradict the limit.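

No step in size can be read from compound 1 to compound 4, because both stop at the same limit: the limit of > 100000 nM in this assay, at which 4 of the 4 values shown sit.

The compounds shown leave open whether 3-fluorophenyl and 2-fluorophenyl differ at all in strength of inhibition.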